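A few compounds are considered here, and "the series" means these few. Any claim that something is new, unique, unknown or untested is made for them only; others in the source may bear on it.

Compound 1 `CCCN1CCC(c2noc(COc3ccc(/C=C/C(=O)NO)cc3)n2)CC1` was examined in an assay on isolated protein for inhibition of protein deacetylase HDAC6 (Homo sapiens), read by fluorescence, with a stated time of 1 h, tested at 100 nM (on this read-out lower numbers stand for less inhibition and higher numbers for more inhibition at the one concentration tested (going by the name of the read-out)), where compound 1 gives 69%. Among the measured compounds shown here, its one measured neighbour, compound 2 `O=C(/C=C/c1ccc(OCc2nc(C3CCN(Cc4ccccc4)CC3)no2)cc1)NO`, gives 71% in this assay; the step of a number 2 percentage points higher from compound 1 to compound 2 (within the scatter) and arises from phenyl in place of ethyl on a saturated chain carbon bound to an amine nitrogen in a ring. Of the two numbers shown, that of compound 1 is the lower, by a margin within the scatter, so nothing separates the two compounds on this read-out.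

Compound 3 `CCCN1CCC(c2noc(COc3ccc(CCC(=O)NO)cc3)n2)CC1` differs from compound 1 in a single place: 2-(hydroxycarbamoyl)ethyl in place of 2-(hydroxycarbamoyl)ethenyl on an aromatic carbon. No measured step bears on this change; the only step shown alters the group on the amine nitrogen in a ring and stays within the scatter, so it offers no guide to a change on the aromatic carbon. The expectation for compound 3 therefore rests on the value of compound 1 alone and is held loosely. In this assay compound 3 is expected to give 50%, with a range from 25% to 72%. The expected step of a number 19 percentage points lower from compound 1 to compound 3 (beyond the scatter) is a modest fall, though the range admits no change at all.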

Compound 3, a percentage reported as inhibition, at one concentration (the size of the read-out at that concentration, not a potency): 13%
Beside the measured number, compound 3's estimate is 37 percentage points above it; measured number below the stated range.
By their numbers in this assay, from the lowest: compound 3; then compounds 1 and 2 (each within the scatter of the next).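

In this assay, among the compounds shown here, 2-(hydroxycarbamoyl)ethyl in place of 2-(hydroxycarbamoyl)ethenyl on the aromatic carbon para to a large group gives a number 56 percentage points lower from compound 1 to compound 3 (beyond the scatter), so this position is sensitive to a change that the earlier compounds did not touch, whereas the change on the amine nitrogen in a ring gave only a number 2 percentage points higher from compound 1 to compound 2 (within the scatter). The two groups match in heavy atoms, hydrogen-bond donors and hydrogen-bond acceptors, and the counted difference is the double bonds outside aromatic rings, 2 in the group that leaves and 1 in the group that enters, so the large step goes with the loss of the carbon-carbon double bond of the chain. For the compounds shown here, nothing at hand tells why this loss lowers the number so far.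

From the compounds shown here alone, it stays open whether the same change would cost as much with the benzyl group of compound 2 on the amine nitrogen, since the step is read on the propyl-bearing compounds alone. Going by these compounds, it is also open how this position would respond to a longer chain such as 3-(hydroxycarbamoyl)propyl, or to a carboxylic acid in place of the hydroxycarbamoyl group at the end of the chain.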